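This account rests on a few compounds, and the source may have more. Where it says the series, first, only, none or still open, it means among the compounds named here.

The study compares four compounds built on a shared core. Compound 1 `C[C@]1(O)C[C@@](c2cccc(C(F)(F)F)c2)([C@H](O)c2ccccn2)C1` and compound 2 `C[C@]1(O)C[C@@](c2ccc(C(F)(F)F)cc2)([C@H](O)c2ccccn2)C1` have the same atoms joined differently; the difference between the two cores is not broken down here. In an ADME assay on liver for metabolic stability, with Liver microsome (Homo sapiens) as the target, read by LC-MS, using microsomes, with a stated time of 5 h (on this read-out higher numbers stand for fast clearance and lower numbers for slow clearance), compound 1 gives 150 mL/min/kg, the highest of the three measured numbers, while compound 2 gives 50 mL/min/kg. Compound 3 `C[C@]1(O)C[C@@](c2ccc(OC(F)(F)F)cc2)([C@H](O)c2ccccn2)C1` is reached from compound 2 through (trifluoromethoxy in place of trifluoromethyl on an aromatic carbon), and in this assay compound 3 gives 66.7 mL/min/kg, so that a 1.3-fold higher number from compound 2 to compound 3 (0.13 log units; within the scatter). Compound 4 `C[C@]1(O)C[C@@](c2cccc(OC(F)(F)F)c2)([C@H](O)c2ccccn2)C1` is related to compound 1 by the same kind of change, (trifluoromethoxy in place of trifluoromethyl on an aromatic carbon), here made meta to a large group rather than para to a large group. Resting on a 1.3-fold higher number from compound 2 to compound 3 (0.13 log units; within the scatter), the step of a 1.2-fold higher number from compound 1 to compound 4 (0.07 log units; within the scatter) is expected in this assay. Compound 4 is therefore estimated at 175 mL/min/kg in this assay, within a range from 110 mL/min/kg to 280 mL/min/kg.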

Compound 4, clearance: 167 mL/min/kg
Compound 4: the middle estimate sits 1.0-fold (0.02 log units) above what was measured, and the stated range covers the measured number.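

In this assay, trifluoromethoxy in place of trifluoromethyl on an aromatic carbon comes out as a 1.1-fold higher number from compound 1 to compound 4 (0.05 log units; within the scatter). Set beside the earlier case, the two readings agree: the same change on two cores in this assay, a 1.3-fold higher number (0.13 log units; within the scatter) from compound 2 to compound 3 and a 1.1-fold higher number (0.05 log units; within the scatter) from compound 1 to compound 4, 1.2-fold (0.08 log units) apart, within the scatter of two such steps

For the compounds shown here, this shows that, on these two cores, the change gave no step beyond the scatter, but it rests on only two pairs and does not show that the same would hold on any other core or explain why the numbers are as they are. The compounds shown carry only trifluoromethyl and trifluoromethoxy on this aromatic ring. As far as these compounds go, how a nitrile, an amine or a carboxylic acid in the same place would read remains open.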